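A few compounds are considered here, and "the series" means these few. Any claim that something is new, unique, unknown or untested is made for them only; others in the source may bear on it.

Measured compounds:
- compound 1, `COc1ccc(S(=O)(=O)N2C[C@H](NC(=O)CCCNC(=O)OC(C)(C)C)C[C@@H]2C(=O)NO)cc1`: 49 nM
- compound 2, `COc1ccc(S(=O)(=O)N2C[C@H](NC(=O)[C@H](CCCCN)NC(=O)OC(C)(C)C)C[C@@H]2C(=O)NO)cc1`: 27 nM

In an assay on isolated protein for inhibition of matrix metalloproteinase-9 (Homo sapiens), read by fluorescence (on this read-out lower numbers stand for stronger inhibition and higher numbers for weaker inhibition), compound 1 gives 49 nM and compound 2 gives 27 nM. Compound 2 thus has the lower of the two numbers, yet the gap to compound 1 lies within the usual scatter, so the two cannot be ordered on this evidence. Going by the values given here, no single-point step between these measured compounds exists, so nothing about the size of any change can be read from them.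

Compound 3, `COc1ccc(S(=O)(=O)N2C[C@H](NC(=O)[C@@H](N)CCCCN)C[C@@H]2C(=O)NO)cc1`, is still to be tested in this assay. It differs from compound 2 by hydrogen in place of tert-butoxycarbonyl on an amine nitrogen, which is hydrogen in place of tert-butoxycarbonyl on an amine nitrogen. Among the compounds with values here, with no comparable step available, the expectation rests on compound 2 alone: the step from compound 2 to compound 3 is estimated as a 1.5-fold higher number from compound 2 to compound 3 (0.17 log units; within the scatter), a small move towards a higher number that may not exceed the scatter. Compound 3 is therefore expected to give about 40 nM, within 15 nM to 120 nM.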

Compound 3, half-maximal inhibitory concentration: 5.7 nM
Estimate against measurement, compound 3: 7.0-fold (0.85 log units) above; the measured number lies below the stated range.
By their numbers in this assay, from the lowest: compound 3; then compounds 2 and 1 (each within the scatter of the next).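

Hydrogen in place of tert-butoxycarbonyl on this amine nitrogen brings a 4.7-fold lower number from compound 2 to compound 3 (0.68 log units; beyond the scatter) in this assay, so the tert-butoxycarbonyl group is not needed for inhibition here, and compound 3, with its free amine, has the lowest number of the three. The wider change, 1,5-diaminopentyl in place of 3-((tert-butoxycarbonyl)amino)propyl on a carbonyl carbon, brings an 8.6-fold lower number from compound 1 to compound 3 (0.93 log units; beyond the scatter), whereas compounds 1 and 2, which both carry tert-butoxycarbonyl, could not be told apart. Nothing measured on these compounds accounts for the step.

As far as these compounds go, whether the free amine itself matters, or only the loss of tert-butoxycarbonyl, stays open, and an acetyl or methyl group on the same nitrogen would separate the two. Also open, from the compounds shown here alone, is what the other amine of the 1,5-diaminopentyl group contributes, which a carboxylic acid there or a shorter chain would address.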